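The source may report more compounds than this note shows. Statements on the series, on what has been measured and on what is new or still open speak of the compounds shown alone.

Two compounds built on a shared core, compound 1 `O=C(N/N=C/c1ccccc1F)c1cnccn1` and compound 2 `O=C(N/N=C/c1ccc(Br)cc1)c1cnccn1`, have been tested in an ADME assay on J774 cells (Mus musculus) for cytotoxicity, read by MTT assay, with a stated time of 48 h, tested at 50 ug/mL; a lower number here means a stronger effect, a higher number a weaker effect of the compound at the concentration tested. In this assay compound 1 gives 100%, and compound 2 gives 100%. Compound 2 thus stands level with compound 1 at the digits shown; the two values lie within the usual scatter of such measurements, so no order between them can be read. Compound 3 `O=C(N/N=C/c1ccc(O)cc1)c1cnccn1` has not yet been measured. It differs from compound 2 in one place: hydroxy in place of bromo on an aromatic carbon. Within the data shown here, no step between measured compounds carries this change, so the expectation for compound 3 rests on the two values alone. Because compound 2 gives 100%, with no effect at the concentration tested, compound 3 is expected to show no step beyond the scatter, no change at the digits printed from compound 2 to compound 3 (within the scatter). The estimate for compound 3 in this assay is 100%, in the range 88% to 105%.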

Compound 3, a percentage reported as activity, at one concentration (the size of the read-out at that concentration, not a potency): 100%
The estimate for compound 3 equals the measured number at the digits printed; low and high end bracket the measured number.
By their numbers in this assay, from the lowest: compounds 1, 2 and 3 (each within the scatter of the next).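

In this assay, among these compounds, hydroxy in place of bromo on an aromatic carbon, para to a large group, gives no change at the digits printed from compound 2 to compound 3 (within the scatter) and so adds the first measured step at this position. The change brings in a hydrogen-bond donor and a hydrogen-bond acceptor where bromo has neither, yet compound 3 still shows no effect at the concentration tested, so this swap does not separate the two compounds here. Nothing available explains this result.

Going by these compounds, it remains open whether an amine, a carboxylic acid or a longer chain such as butoxy on this same carbon would move the read-out away from this level. On these data alone, whether compound 2 and compound 3 would also stay level at a higher concentration remains open too.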